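The source may hold more compounds than are shown below. What is called first, only, known or untested is meant among the compounds shown, and "the series" means these compounds.

Measured compounds:
compound 1, `COc1ccc(CNC(=O)/C(C#N)=C/c2ccc(C)o2)cc1`, 58000 nM in a functional assay on A-431 cells (Homo sapiens) for inhibition, read by MTT assay, with a stated time of 72 h; on this read-out higher numbers stand for weaker inhibition of growth and lower numbers for stronger inhibition of growth
compound 2, `COc1ccc(CNC(=O)/C(C#N)=C/c2ccc(-c3ccccc3)o2)cc1`, > 100000 nM in this assay

Going by the values given here, compound 1 holds the only numerical value in this assay; the other value is a limit of the assay. For compound 2 the value is such a limit, (the limit of > 100000 nM in this assay, at which 1 of the 2 values shown sits). Among the compounds with values here, the one step between measured compounds, an at least 1.7-fold higher number from compound 1 to compound 2 (0.23 log units; that floor lies within the scatter), exchanges phenyl for methyl on an aromatic carbon and its floor lies within the scatter.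

Compound 3, `COc1ccc(CNC(=O)/C(C#N)=C/c2ccoc2)cc1`, has not yet been measured in this assay. It differs from compound 1 by furan-3-yl in place of 5-methylfuran-2-yl on a double-bonded chain carbon bound to a double-bonded chain carbon. Within the data shown here, no measured step covers this change: the step from compound 1 to compound 2 alters the substituent on the furan rather than removing it and shifting the attachment point, so it offers only a weak guide. Without closer precedent, the step of a 1.2-fold higher number from compound 1 to compound 3 (0.08 log units; within the scatter) is expected to stay within the scatter or to lean toward weaker inhibition, given how little room lies between compound 1 and the limit. Compound 3 is therefore estimated at 70000 nM, with a range from 25000 nM to 200000 nM.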

Compound 3, concentration for 50% growth inhibition: 5000 nM
Compound 3: middle estimate off by 14-fold (1.15 log units), on the high side; measured number outside the range, below it.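

In this assay, the place on a double-bonded chain carbon bound to a double-bonded chain carbon proves able to move the read-out well beyond the scatter: furan-3-yl in place of 5-methylfuran-2-yl gives a 12-fold lower number from compound 1 to compound 3 (1.06 log units; beyond the scatter). Going by these compounds alone, the only earlier step, an at least 1.7-fold higher number from compound 1 to compound 2 (0.23 log units; that floor lies within the scatter), put phenyl in place of methyl on an aromatic carbon, and its floor stayed within the scatter, so it gave no sign that a change between two closely matched rings, each a five-membered aromatic ring with 1 hetero atom, could carry a step of this size. Nothing shown here bears on why this step is so large.

From the compounds shown here alone, the change removes the methyl and shifts the point of attachment in a single step, so it remains open which of the two carries the gain, and whether a plain furan-2-yl or a 5-methylfuran-3-yl group would keep it. Going by these compounds, it is also open whether a thiophen-3-yl or pyridin-3-yl ring at this place, or an aminomethyl group or a carboxylic acid on the furan-3-yl, would hold the stronger inhibition of growth seen with compound 3.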